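The source may report more compounds than this note shows. Statements on the series, on what has been measured and on what is new or still open speak of the compounds shown alone.

Working notes on the series. Compound 1 `Cn1cc(NC(=O)c2ccc(NS(=O)(=O)c3ccccc3)cc2)cn1`, compound 2 `Cc1ccc(-n2cc(NC(=O)c3ccc(NS(=O)(=O)c4ccccc4)cc3)cn2)cc1` and compound 3 `COc1cccc(-n2cc(NC(=O)c3ccc(NS(=O)(=O)c4ccccc4)cc3)cn2)c1` share one core and differ only in the group on the aromatic nitrogen. In a functional assay on HeLa cells (Homo sapiens) for inhibition, read by MTT assay, with a stated time of 48 h (a lower number here means a stronger inhibitor, a higher number a weaker inhibitor), compound 1 gives 92800 nM, compound 2 gives 27900 nM and compound 3 gives 66200 nM. Compound 2 stands lowest of the three measured: a 3.3-fold lower number from compound 1 to compound 2 (0.52 log units; beyond the scatter) and a 2.4-fold higher number from compound 2 to compound 3 (0.38 log units; beyond the scatter) both lie beyond the scatter, whereas a 1.4-fold lower number from compound 1 to compound 3 (0.15 log units; within the scatter) does not. Compound 4 `Cc1ccc(-n2cc(NC(=O)c3ccc(NS(=O)(=O)c4ccc(Cl)cc4)cc3)cn2)cc1` keeps the 4-methylphenyl of compound 2 and changes at the other end of the molecule: chloro in place of hydrogen on an aromatic carbon. Among the measured compounds shown here, no measured step touches this ring; all three measured steps vary the group on the aromatic nitrogen, so there is no precedent for a chloro entering at this place. For compound 4 the expected step of a 1.3-fold lower number from compound 2 to compound 4 (0.10 log units; within the scatter) is accordingly one within the scatter, with no direction claimed. Compound 4 is estimated at 22000 nM in this assay, with a range of 8000 nM to 60000 nM.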

Compound 4, half-maximal inhibitory concentration: 8010 nM
Estimate against measurement, compound 4: 2.7-fold (0.44 log units) above; low and high end bracket the measured number.
By their numbers in this assay, from the lowest: compound 4; then compound 2; then compounds 3 and 1 (each within the scatter of the next).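

In this assay, among the compounds shown here, chloro in place of hydrogen on an aromatic carbon of the phenylsulfonyl end gives a 3.5-fold lower number from compound 2 to compound 4 (0.54 log units; beyond the scatter) and so shows that this ring, untouched by the earlier steps, is a place where the number moves beyond the scatter. One heavy atom entering here gives a step that is also graded modest, like a 3.3-fold lower number from compound 1 to compound 2 (0.52 log units; beyond the scatter) on the aromatic nitrogen, so both ends of the molecule respond in this assay. No measurement at hand bears on the cause of this step.

Chloro is seen here only with the 4-methylphenyl group on the aromatic nitrogen, so whether the step carries over to the methyl of compound 1 or the 3-methoxyphenyl of compound 3 stays open. Also open, from the compounds shown here alone, is whether fluoro, methoxy or an amine at the same place would move the number the same way.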